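Swapping the aryl ring on a cytotoxicity scaffold

The source may hold more compounds than are shown below. What is called first, only, known or untested is meant among the compounds shown, and "the series" means these compounds.

Of the compounds shown here, two sharing one core have been tested in an ADME assay on NIH3T3 cells (Mus musculus) for cytotoxicity, read by MTT assay; a lower number here means a stronger inhibitor, a higher number a weaker inhibitor. Compound 1 `N#Cc1c(-c2ccccc2O)c(C#N)c(=O)n(/N=C/c2cn(-c3ccccc3)nc2-c2ccccc2)c1N` gives 162 ug/mL. Among the compounds with values here, compound 2 `COc1cc(-c2c(C#N)c(N)n(/N=C/c3cn(-c4ccccc4)nc3-c3ccccc3)c(=O)c2C#N)cc(OC)c1OC` gives 64 ug/mL, the lowest of the two numbers so far, with compound 1 as its only neighbour. Within the data shown here, the single measured step, a 2.5-fold lower number from compound 1 to compound 2 (0.40 log units; beyond the scatter), shows that exchanging the aryl ring on this aromatic carbon can move the number beyond the scatter.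

Compound 3 `N#Cc1c(-c2cccc([N+](=O)[O-])c2)c(C#N)c(=O)n(/N=C/c2cn(-c3ccccc3)nc2-c2ccccc2)c1N` changes that same aryl ring again: 3-nitrophenyl in place of 3,4,5-trimethoxyphenyl on an aromatic carbon. Among the measured compounds shown here, no measured step covers a nitro-bearing ring on this position, so the only guide is that the one known exchange there, a 2.5-fold lower number from compound 1 to compound 2 (0.40 log units; beyond the scatter), was modest, and that neither measured aryl ring matches the new one. In this assay the step is therefore expected to stay small either way; the estimated step of a 1.6-fold higher number from compound 2 to compound 3 (0.19 log units; within the scatter) points to a somewhat higher number, about midway back toward compound 1. Compound 3 is estimated at 100 ug/mL, within a range from 45 ug/mL to 220 ug/mL.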

Compound 3, half-maximal inhibitory concentration: 124 ug/mL
Compound 3: middle estimate off by 1.2-fold (0.09 log units), on the low side, and the stated range covers the measured number.
By their numbers in this assay, from the lowest: compounds 2, 3 and 1 (each within the scatter of the next, the first and the last beyond it).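

In this assay, moving to the 3-nitrophenyl ring gives a 1.9-fold higher number from compound 2 to compound 3 (0.29 log units; within the scatter), and the comparison from the other measured ring gives a 1.3-fold lower number from compound 1 to compound 3 (0.12 log units; within the scatter). Compound 3 therefore cannot be told apart from either neighbour on this aromatic carbon, even though compound 1 and compound 2 are separated beyond the scatter, and swapping a ring of 12 heavy atoms for one of 9 does not produce a readable change here. No measurement shown here accounts for where compound 3 falls relative to the other two.

Going by these compounds, it remains open whether this position can move the number further with a different kind of substituent, such as an aryl ring carrying an amine or a carboxylic acid, or a longer alkyl chain in place of the aryl ring. All three compounds also keep the rest of the shared core fixed, so these comparisons cannot show how replacing either of the two cyano groups, or the amino group, would change the number, or whether the aryl ring would matter as little in such compounds.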